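Furan to thiophene on a shared core

The source may report more compounds than this note shows. Statements on the series, on what has been measured and on what is new or still open speak of the compounds shown alone.

Two compounds share a core carrying a 3-hydroxyphenyl group and a 3-chlorophenyl group. Compound 1 `Oc1cccc(-c2cc(-c3ccncc3)nc(-c3cccc(Cl)c3)c2)c1` bears a pyridin-4-yl group; in an assay on isolated protein for inhibition of DNA topoisomerase 1 (Homo sapiens), with a stated time of 30 min, tested at 100 uM (on this read-out lower numbers stand for a weaker effect and higher numbers for a stronger effect at the one concentration tested), compound 1 gives 0%. Compound 2 `Oc1cccc(-c2cc(-c3cccc(Cl)c3)nc(-c3ccco3)c2)c1` bears a furan-2-yl group instead, and in this assay compound 2 gives 5.5%. Among the measured compounds shown here, the only step available is a number 5.5 percentage points higher from compound 1 to compound 2 (within the scatter), so the two numbers cannot be told apart, and compound 2 stands together with compound 1 at the low end of what this read-out can show.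

Compound 3 `Oc1cccc(-c2cc(-c3cccc(Cl)c3)nc(-c3cccs3)c2)c1` is the next member. It differs from compound 2 in one place: thiophen-2-yl in place of furan-2-yl on an aromatic carbon. For the measured compounds named here, no measured step covers this exchange of one five-membered aromatic ring for another. Going by the values given here, the one step known, from compound 1 to compound 2, swapped a six-membered ring for the furan-2-yl group and stayed within the scatter. The account therefore expects no step beyond the scatter for compound 3 in this assay, namely a number 0.5 percentage points lower from compound 2 to compound 3 (within the scatter). Compound 3 is estimated at 5%, with a range from 0% to 15%.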

Compound 3, a percentage reported as inhibition, at one concentration (the size of the read-out at that concentration, not a potency): 7.6%
Beside the measured number, compound 3's estimate is 2.6 percentage points below it; low and high end bracket the measured number.
By their numbers in this assay, from the lowest: compounds 1, 2 and 3 (each within the scatter of the next).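

The exchange of furan-2-yl for thiophen-2-yl, on the aromatic carbon next to the ring nitrogen, tests one five-membered aromatic ring with a single hetero atom against another, with oxygen replaced by sulfur, and in this assay it gives a number 2.1 percentage points higher from compound 2 to compound 3 (within the scatter). The direct exchange of the six-membered pyridin-4-yl group for thiophen-2-yl gives a number 7.6 percentage points higher from compound 1 to compound 3 (within the scatter), so this read-out does not separate any pair among the pyridin-4-yl, furan-2-yl and thiophen-2-yl compounds. Nothing measured on these compounds beyond this read-out bears on the result.

From the compounds shown here alone, all three groups at this position are aromatic rings, so it remains open whether a primary amine, a carboxylic acid or a longer alkyl chain on the same carbon would give a number beyond the scatter. Also open, going by these compounds, is whether thiophen-3-yl, which attaches the same ring through a different carbon, would stand with compound 3 or apart from it.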